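Methyl for bromo on the sulfonyl aryl of compound 1

This account rests on a few compounds, and the source may have more. Where it says the series, first, only, none or still open, it means among the compounds named here.

Measured so far in a functional assay on SK-MEL-28 cells (Homo sapiens) for cytotoxicity, read by MTT assay; on this read-out lower numbers stand for stronger inhibition and higher numbers for weaker inhibition:
compound 1 `O=S(=O)(NCCCNc1nccc(-c2c(-c3cccc(F)c3)nc3sccn23)n1)c1ccc(Br)cc1` gives 9400 nM
compound 2 `O=C(NCCNc1nccc(-c2c(-c3cccc(F)c3)nc3sccn23)n1)c1c(F)cccc1F` gives 11400 nM
compound 3 `O=C(NCCCNc1nccc(-c2c(-c3cccc(F)c3)nc3sccn23)n1)c1ccc(Cl)cc1` gives > 20000 nM

For compound 3 the value is a limit of the assay and not a number (the limit of > 20000 nM in this assay, at which 1 of the 3 values shown sits). Among the two numbers, compound 1 stands lowest, with compound 2 its nearest neighbour: a 1.2-fold higher number from compound 1 to compound 2 (0.08 log units; within the scatter). The step of an at least 2.1-fold higher number from compound 1 to compound 3 (0.32 log units; beyond the scatter) and the step of an at least 1.7-fold higher number from compound 2 to compound 3 (0.24 log units; that floor lies within the scatter) both run to that limit.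

Compound 4 `Cc1ccc(S(=O)(=O)NCCCNc2nccc(-c3c(-c4cccc(F)c4)nc4sccn34)n2)cc1` differs from compound 1 only by methyl in place of bromo on an aromatic carbon, so that the ((4-bromophenyl)sulfonyl)amino group becomes ((4-methylphenyl)sulfonyl)amino. Going by the values given here, none of the measured steps touch this position: the step from compound 1 to compound 2 and the step from compound 2 to compound 3 alter the chain and its attached group, and the step from compound 1 to compound 3 exchanges the sulfonyl for a carbonyl. Among the compounds with values here, no measured step therefore bears on the change, and in this assay no step beyond the scatter is expected: a 1.1-fold higher number from compound 1 to compound 4 (0.03 log units; within the scatter). Compound 4 is estimated at 10000 nM, between 4500 nM and 22000 nM.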

Compound 4, half-maximal inhibitory concentration: 9500 nM
Compound 4: the middle estimate sits 1.1-fold (0.02 log units) above what was measured, within the range that was stated.
By their numbers in this assay, from the lowest: compounds 1, 4 and 2 (each within the scatter of the next). At a limit, above all of these: compound 3.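

In this assay, the position on the aromatic carbon para to a large group shows no response to this change: with a 1.0-fold higher number from compound 1 to compound 4 (0.00 log units; within the scatter), 4-bromophenyl and 4-methylphenyl cannot be told apart on the sulfonyl. The other numbered comparison also stays within the scatter, with a 1.2-fold lower number from compound 2 to compound 4 (0.08 log units; within the scatter). Compound 3 carries a limit of the assay and not a number, and an at least 2.1-fold lower number from compound 3 to compound 4 (0.32 log units; beyond the scatter) places the (4-methylphenyl)sulfonyl compound clear of that limit, as the step from the bromo compound already did: the limit of > 20000 nM in this assay, at which 1 of the 4 values shown sits.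

Whether the flat response holds for other groups at this position, such as methoxy, nitrile or a carboxylic acid, remains open, since the compounds shown carry only bromo and methyl there. Also open, from the compounds shown here alone, is whether a longer chain in the sulfonyl compounds would move these numbers.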